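The source may report more compounds than this note shows. Statements on the series, on what has been measured and on what is new or still open speak of the compounds shown alone.

Compound 1 `CCCn1c(-c2ccccc2)nc2c(NC3CCCC3)ncnc21`: in a functional assay on CHO cells for antagonist activity at adenosine receptor A2b (Homo sapiens), read by 33P incorporation, with a stated time of 20 min (a lower number here means a stronger inhibitor, a higher number a weaker inhibitor), compound 1 gives 3430 nM.
Compound 2 `Cn1c(-c2ccc(O)cc2)nc2c(NC3CCCC3)ncnc21`: compound 2 gives 17800 nM.
Compound 3 `Cc1ccccc1-c1nc2c(NC3CCCC3)ncnc2n1C`: compound 3 gives only a limit of the assay, > 30000 nM.

Compound 3 thus stands at the limit of > 30000 nM in this assay, at which 1 of the 3 values shown sits, the weakest reading shown, with no exact number. Compound 4 `Cn1c(-c2ccccc2)nc2c(NC3CCCC3)ncnc21` differs from it by hydrogen in place of methyl on an aromatic carbon. Within the data shown here, the one comparable step, an at least 1.6-fold higher number from compound 2 to compound 3 (0.22 log units; that floor lies within the scatter), shows that changing the group on that phenyl ring can move the number, though its size is uncertain. Compound 1, with phenyl and a propyl group, gives the lowest value shown, and compound 4 also carries a plain phenyl. Compound 4 is therefore expected to give a real number, estimated at 10000 nM (range 3000 nM to 30000 nM), a step of an at least 3.0-fold lower number from compound 3 to compound 4 (0.47 log units; beyond the scatter) in this assay.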

Compound 4, inhibition constant: 8510 nM
Compound 4: the middle estimate sits 1.2-fold (0.07 log units) above what was measured, within the range that was stated.
By their numbers in this assay, from the lowest: compound 1; then compound 4; then compound 2. At a limit, above all of these: compound 3.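

Going from 2-methylphenyl to phenyl gives an at least 3.5-fold lower number from compound 3 to compound 4 (0.54 log units; beyond the scatter), and since compound 3 stands at a limit of the assay, that size is only a floor. Hydrogen in place of hydroxy on the same ring gives a 2.1-fold lower number from compound 2 to compound 4 (0.32 log units; beyond the scatter), so both ring groups shown go with a higher number than plain phenyl. With phenyl held fixed, methyl in place of propyl on the aromatic nitrogen gives a 2.5-fold higher number from compound 1 to compound 4 (0.39 log units; beyond the scatter), so the longer chain goes with the lower number here.

The compounds shown leave open how an amine or a carboxylic acid on the phenyl ring would read. They also leave open whether a butyl chain on that nitrogen would lower the number further.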